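This account rests on a few compounds, and the source may have more. Where it says the series, first, only, none or still open, it means among the compounds named here.

Compound 1 `Cc1cccc(NC(=O)NCC2(c3ccccc3)CCCCC2)c1` in an assay on microsomes from intestine for inhibition of acyl-CoA:cholesterol acyltransferase (Oryctolagus cuniculus) (on this read-out lower numbers stand for stronger inhibition and higher numbers for weaker inhibition), gives 2800 nM. Compound 2 `O=C(NCC1(c2ccccc2)CCCCC1)Nc1ccc(Cl)cc1` in this assay gives 2200 nM, and compound 3 `O=C(NCC1(c2ccccc2)CCCCC1)Nc1ccc(Cl)c(Cl)c1` in this assay gives 3800 nM. Compound 3 thus shows the largest of the three numbers, yet its distance to each of the others stays within the scatter: a 1.4-fold higher number from compound 1 to compound 3 (0.13 log units; within the scatter) and a 1.7-fold higher number from compound 2 to compound 3 (0.24 log units; within the scatter). Compound 4 `O=C(NCC1(c2ccccc2)CCCCC1)Nc1cc(Cl)ccc1Cl` differs from compound 3 in a single place, (2,5-dichlorophenyl in place of 3,4-dichlorophenyl on an amide-type nitrogen); the two share the same atoms, joined differently. The measured steps that bear on this change are the variations of the substituted phenyl on the amide-type nitrogen: a 1.3-fold lower number from compound 1 to compound 2 (0.10 log units; within the scatter), a 1.4-fold higher number from compound 1 to compound 3 (0.13 log units; within the scatter) and a 1.7-fold higher number from compound 2 to compound 3 (0.24 log units; within the scatter), none of which left the scatter. A different arrangement of the same atoms on that phenyl ring is therefore expected to produce no step beyond the scatter in this assay, so that the expected change is a 1.1-fold lower number from compound 3 to compound 4 (0.04 log units; within the scatter). Compound 4 is estimated at 3500 nM, with a range from 1500 nM to 8000 nM.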

Compound 4, half-maximal inhibitory concentration: 2700 nM
Compound 4: middle estimate off by 1.3-fold (0.11 log units), on the high side; measured number inside the range.
By their numbers in this assay, from the lowest: compounds 2, 4, 1 and 3 (each within the scatter of the next).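

In this assay, going by these compounds alone, the swap of 3,4-dichlorophenyl for 2,5-dichlorophenyl on the amide-type nitrogen gives a 1.4-fold lower number from compound 3 to compound 4 (0.15 log units; within the scatter) and so shows that rearranging the same atoms on this ring, a change the earlier compounds did not cover, leaves the number within the scatter. The steps of a 1.2-fold higher number from compound 2 to compound 4 (0.09 log units; within the scatter) and a 1.0-fold lower number from compound 1 to compound 4 (0.02 log units; within the scatter) are also within the scatter, so none of the four substituted phenyl groups at this position stands apart from the others. Nothing measured here accounts for how close these numbers lie.

Going by these compounds, all four groups are phenyl rings bearing only chloro or methyl, so it stays open whether a pyridine ring, a carboxylic acid or an amine at this position would produce a step beyond the scatter. The compounds also leave open how much changes to the shared core would matter, since it is the same in all four.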